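The compounds below may be only part of what the source reports. "The series", "measured", "known", "first", "only" and "open" are said of these compounds alone.

Compound 1 `CC(=O)n1cc(C(=O)O)c(Nc2ccc(I)cc2F)c1C`: 0.35 h
Compound 2 `CC(=O)c1cc(C(=O)O)c(Nc2ccc(I)cc2F)n1C`: 0.117 h
Compound 3 `CC(=O)c1cc(C(=O)NOCCCO)c(Nc2ccc(I)cc2F)n1C`: 0.217 h

These three compounds were measured in an in vitro ADME assay on microsomes from liver (Rattus norvegicus) for metabolic stability; on this read-out lower numbers stand for a shorter-lived compound and higher numbers for a longer-lived compound. Compound 3 sits within the usual scatter of both compound 1 and compound 2, so none of the three can be set apart from the others on this read-out. Compound 4 `CC(=O)c1cc(C(=O)N2CC(O)C2)c(Nc2ccc(I)cc2F)n1C` is the unmeasured compound. It differs from compound 3 by 3-hydroxyazetidin-1-yl in place of (3-hydroxypropoxy)amino on a carbonyl carbon. The only measured step at that carbonyl carbon is a 1.9-fold higher number from compound 2 to compound 3 (0.27 log units; within the scatter), and no measured pair shows a ring entering there, so nothing shown points to a step beyond the scatter. Compound 4 is therefore expected to give about 0.25 h in this assay, between 0.1 h and 0.6 h, which means an expected step of a 1.2-fold higher number from compound 3 to compound 4 (0.06 log units; within the scatter).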

Compound 4, half-life: 0.217 h
Compound 4: middle estimate off by 1.2-fold (0.06 log units), on the high side, and the stated range covers the measured number.
By their numbers in this assay, from the lowest: compounds 2, 3, 4 and 1 (each within the scatter of the next, the first and the last beyond it).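

With a ring now on the carbonyl carbon, 3-hydroxyazetidin-1-yl in place of (3-hydroxypropoxy)amino gives (no change at the digits printed from compound 3 to compound 4 (within the scatter)) in this assay. Measured against hydroxy at the same carbon, the same ring gives (a 1.9-fold higher number from compound 2 to compound 4 (0.27 log units; within the scatter)), so all three groups lie within the scatter of one another at this place. There is no evidence to say why these numbers fall as they do.

On these data alone, whether a larger ring such as piperidine or an azetidine without the hydroxy group would give a step beyond the scatter stays open. So does the effect of a longer chain on the carbonyl carbon.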